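The compounds below may be only part of what the source reports. "The series", "measured", "known", "first", "only" and "open" are said of these compounds alone.

Measured compounds:
Compound 1, `CCN(CC)CCCOc1cc2ncnc(Nc3nc4ccc(C(=O)Nc5c(C)cccc5C)cc4s3)c2cc1OC` — in a functional assay on NCI-H661 cells (Homo sapiens) for cytotoxicity, read by WST assay, with a stated time of 72 h (a higher number here means a weaker inhibitor, a lower number a stronger inhibitor), compound 1 gives 66500 nM.
Compound 2, `COc1cc2c(Nc3nc4ccc(C(=O)Nc5c(C)cccc5C)cc4s3)ncnc2cc1OCCCN1CCCCC1` — in this assay compound 2 gives only a limit, > 100000 nM.

Among the measured compounds shown here, compound 1 carries the only actual number in this assay; the other value is a limit, (the limit of > 100000 nM in this assay, at which 1 of the 2 values shown sits). For the measured compounds named here, the single measured step, an at least 1.5-fold higher number from compound 1 to compound 2 (0.17 log units; that floor lies within the scatter), concerns the amine at the end of the chain, and its floor lies within the scatter, so it shows no clear change.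

Compound 3, `CCN(CC)CCCOc1cc2ncnc(Nc3nc4ccc(C(=O)Nc5c(C)cc(C)cc5C)cc4s3)c2cc1OC`, differs from compound 1 by methyl in place of hydrogen on an aromatic carbon. Going by the values given here, no measured step touches the aryl of the carbamoyl group, so the one step that has been measured does not bear directly on this change. With compound 1 already weak in this assay and no evidence pointing either way, the expectation is a step that stays within the scatter: a 1.0-fold lower number from compound 1 to compound 3 (0.01 log units; within the scatter). Compound 3 is therefore estimated at 65000 nM in this assay, with a range from 25000 nM to 160000 nM, and a real chance that only a limit is reported.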

Compound 3, half-maximal inhibitory concentration: 7300 nM
The estimate for compound 3 lay 8.9-fold (0.95 log units) above the measured number; measured number outside the range, below it.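

Among the compounds shown here, the step of a 9.1-fold lower number from compound 1 to compound 3 (0.96 log units; beyond the scatter) is the first change in this assay that lies beyond the scatter, and it shows that the aryl of the carbamoyl group matters in a way the earlier compounds could not reveal. For the compounds shown here, the move from 2,6-dimethylphenyl to 2,4,6-trimethylphenyl adds a single methyl, meta to two methyl groups and para to a large group, and that alone is enough to shift the number, whereas the one earlier step, at the amine on the chain, was an at least 1.5-fold higher number from compound 1 to compound 2 (0.17 log units; that floor lies within the scatter). Nothing shown gives a measured property that would account for this step.

The effect rests on this one pair, so the compounds shown leave open whether methyl is special at this place or whether an ethyl, a methoxy or a chlorine there would do the same. They also leave open whether the same methyl would move the number with piperidin-1-yl at the end of the chain, and whether a phenyl carrying only that one methyl, without the other two methyl groups, would behave like compound 3.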